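Isobutyl esters of two dihydropyrimidine cores at the adenosine receptor

The source may report more compounds than this note shows. Statements on the series, on what has been measured and on what is new or still open speak of the compounds shown alone.

Three compounds were measured in an assay on membranes from CHO cells for displacement of a labelled ligand from adenosine receptor A1 (Homo sapiens), read by scintillation counting, with a stated time of 60 min, tested at 1 uM; on this read-out higher numbers stand for more inhibition at the one concentration tested (going by the name of the read-out) and lower numbers for less inhibition:

compound 1 `CCCOC(=O)C1=C(C)NC(=O)NC1c1cccs1`, 43%
compound 2 `CC1=C(C(=O)OCC(C)C)C(c2cccs2)NC(=O)N1`, 25%
compound 3 `CCCOC(=O)C1=C(C)NC(=S)NC1c1ccoc1`, 4%

Compound 1 and compound 2 share a core and differ by one change, (methyl in place of hydrogen on a saturated chain carbon bound to two saturated chain carbons). This change gives a number 18 percentage points lower from compound 1 to compound 2 (beyond the scatter) in this assay. Compound 3 rests on a different core; the difference between the two cores is not broken down here. Compound 3 stands lowest of the three numbers, below compound 2 and further below compound 1.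

Compound 4 `CC1=C(C(=O)OCC(C)C)C(c2ccoc2)NC(=S)N1` has not yet been measured in this assay. Within the data shown here, it differs from compound 3 by methyl in place of hydrogen on a saturated chain carbon bound to two saturated chain carbons, the same change as the one made from compound 1 to compound 2, at the same place. Among the measured compounds shown here, the one earlier step of this kind lowered the number; on the core of compound 3 the starting number is already low, so there is little room for a drop of the same size, and a small downward move or no visible change is what is expected. For compound 4 the step is therefore expected to be a number 2 percentage points lower from compound 3 to compound 4 (within the scatter) in this assay, resting on compound 3 giving 4% and on the earlier step of a number 18 percentage points lower from compound 1 to compound 2 (beyond the scatter). Compound 4 is estimated to give 2% in this assay, within a range from -10% to 15%.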

Compound 4, a percentage reported as inhibition, at one concentration (the size of the read-out at that concentration, not a potency): 12%
Compound 4: middle estimate off by 10 percentage points, on the low side; low and high end bracket the measured number.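

On the core of compound 3, exchanging the propyl ester for the isobutyl ester gives a number 8 percentage points higher from compound 3 to compound 4 (within the scatter) in this assay, so the clear loss seen on the core of compound 1 does not reappear here. The same change therefore did not carry over from one core to the other with the same size of effect, and the two steps are separated by more than the usual scatter: the same change on two cores in this assay, a number 18 percentage points lower (beyond the scatter) from compound 1 to compound 2 and a number 8 percentage points higher (within the scatter) from compound 3 to compound 4, 26 percentage points apart, beyond the scatter of two such steps. Among these compounds, this shows that, in this series, the result of the change on one core cannot simply be transferred to the other, but it does not show which of the differences between the two cores matters, and with only one pair on each core it gives no general rule for either.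

The compounds shown leave open whether further pairs on these two cores would repeat the same contrast, and whether the two structural differences between the cores would each alter the step if they were taken apart one at a time. They also leave open how a longer chain, or an ester chain ending in an amine or a carboxylic acid, would read on either core.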